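Permeability after adding 4-methylpyridin-2-yl to compound 2

The compounds below may be only part of what the source reports. "The series", "measured", "known", "first", "only" and "open" are said of these compounds alone.

Measured so far:
- compound 1 `C[C@@H](Oc1cc2oc(=O)n(CCC(=O)O)c2cc1Cl)c1cccnn1` gives < 3 nm/s as a limit
- compound 2 `CCOc1cc2oc(=O)n(CCC(=O)O)c2cc1Cl` gives < 10 nm/s as a limit

In a physicochemical assay for permeability, using PAMPA (on this read-out higher numbers stand for higher permeability and lower numbers for lower permeability), compound 2 gives < 10 nm/s as a limit and not as a number. Compound 3 `Cc1ccnc([C@@H](C)Oc2cc3oc(=O)n(CCC(=O)O)c3cc2Cl)c1` arises from compound 2 by one change 4-methylpyridin-2-yl in place of hydrogen on a saturated chain carbon bound to an oxygen on an aromatic ring and a saturated chain carbon that brings in 4-methylpyridin-2-yl, a six-membered aromatic ring with 1 hetero atom, in place of hydrogen. Going by the values given here, the one measured step that bears on this is a step that the two limits leave unreadable from compound 1 to compound 2 in which pyridazin-3-yl gives way to hydrogen at that same place. Its size cannot be read, so it offers no direction. No step beyond the scatter is therefore expected in this assay for this change. The estimated step that the limit leaves unreadable from compound 2 to compound 3 is only an expectation. Compound 3 is estimated at 3 nm/s within an expected range of 1 nm/s to 10 nm/s and another limit is quite possible.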

Compound 3, apparent permeability: < 3 nm/s
Compound 3: a limit, no number (the forecaster's own chance of this, stated with the estimate: 80%); the middle value lies on the limit itself.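

In this assay compound 3 gives < 3 nm/s, a limit and not a number, and the steps from compound 2 to compound 3 and from compound 1 to compound 3 cannot be read. The compounds shown leave open whether swapping the group at this place changes the read-out at all, as compound 1, compound 2 and compound 3 all give only limits.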